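This account rests on a few compounds, and the source may have more. Where it says the series, first, only, none or still open, it means among the compounds named here.

Measured compounds:
Compound 1 `Cc1nc(N)c2nc(-c3ccccc3)sc2n1`: > 30000 nM
Compound 2 `Nc1nc(-c2cccc(O)c2)nc2sc(-c3ccccc3)nc12`: > 30000 nM
Compound 3 `Cc1nc(NC(=O)c2ccccc2)c2nc(-c3ccccc3)sc2n1`: > 30000 nM

In a functional assay on CHO cells for antagonist activity at adenosine receptor A2b (Homo sapiens), read by cAMP accumulation, with a stated time of 10 min (a lower number here means a stronger inhibitor, a higher number a weaker inhibitor), compound 3 gives > 30000 nM, which is a limit of the assay and not a number. Compound 1 gives > 30000 nM in this assay, again a limit. Compound 2 gives > 30000 nM in this assay, also a limit. All three values therefore sit at the same point, (the limit of > 30000 nM in this assay, at which 3 of the 3 values shown sit), so compound 3 cannot be placed above or below either of its neighbours. The two steps measured so far, a step that the two limits leave unreadable from compound 1 to compound 2 and a step that the two limits leave unreadable from compound 1 to compound 3, are both unreadable in size for the same reason.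

Compound 4 `Cc1nc(NC(=O)c2ccc(Cl)cc2)c2nc(-c3ccccc3)sc2n1` differs from compound 3 by chloro in place of hydrogen on an aromatic carbon. Going by the values given here, no measured step bears on this change, and nothing among the three compounds reaches a readable number. The step expected is a number no higher from compound 3 to compound 4 (the limit leaves the size open), none that the assay could resolve. Compound 4 is therefore estimated at 30000 nM, with a range from 5000 nM to 100000 nM, most probably reported as a limit once more.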

Compound 4, half-maximal inhibitory concentration: > 30000 nM
Compound 4: no number, only a limit; the forecaster's own chance of this, stated with the estimate: 80%; the middle value lies on the limit itself.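

In this assay, going by these compounds alone, compound 4 gives > 30000 nM, a limit and not a number, and compound 3 also stands at a limit, so no step from compound 3 to compound 4 can be read. The compounds shown leave open whether chloro in place of hydrogen changes potency at all.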